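This account rests on a few compounds, and the source may have more. Where it says the series, first, only, none or still open, it means among the compounds named here.

Measured in an assay for binding affinity to 5-hydroxytryptamine receptor 1F (Homo sapiens), read by radioligand binding; on this read-out lower numbers stand for stronger inhibition and higher numbers for weaker inhibition:
compound 1 `CC(=O)Nc1cc2c(C3CCN(C)CC3)c[nH]c2cn1`: 210 nM
compound 2 `CCCCCC(=O)Nc1ccc2[nH]cc(C3CCN(C)CC3)c2n1`: 13 nM
compound 3 `CCCCCCCC(=O)Nc1ccc2[nH]cc(C3CCN(C)CC3)c2n1`: 20 nM

Compound 3 stands second highest of the three numbers in this assay, with compound 2 nearest and compound 1 furthest. Compound 4 `CN1CCC(c2c[nH]c3ccc(NC(=O)C4CC4)nc23)CC1` is not yet measured; it differs from compound 3 by cyclopropyl in place of heptyl on a carbonyl carbon. For the measured compounds named here, only one measured step bears on the amide chain: a 1.5-fold higher number from compound 2 to compound 3 (0.19 log units; within the scatter), a change of chain length that stayed within the scatter. Compound 1 carries a shorter acyl group but also a different core, so its number cannot be read as a chain effect alone. Compound 4 is therefore expected to show a 2.3-fold higher number from compound 3 to compound 4 (0.35 log units; beyond the scatter), a modest rise in number, with the estimate for compound 4 at 45 nM within 12 nM to 170 nM.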

Compound 4, inhibition constant: 9.8 nM
Compound 4: middle estimate off by 4.6-fold (0.66 log units), on the high side, outside the stated range (below it).
By their numbers in this assay, from the lowest: compounds 4, 2 and 3 (each within the scatter of the next, the first and the last beyond it); then compound 1.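

On the carbonyl carbon, in this assay, the group need not be an open chain: cyclopropyl in place of heptyl gives a 2.0-fold lower number from compound 3 to compound 4 (0.31 log units; beyond the scatter), and cyclopropyl in place of pentyl gives a 1.3-fold lower number from compound 2 to compound 4 (0.12 log units; within the scatter). The earlier step compared only chains, whereas this result shows that a three-membered ring of carbon is accepted at this place. Nothing measured here accounts for this result. Going by these compounds, whether phenyl or cyclohexyl on the same carbonyl carbon would keep this number remains open. So does how the acetyl group of compound 1 would read on the core of compound 4.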